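A few compounds are considered here, and "the series" means these few. Any claim that something is new, unique, unknown or untested is made for them only; others in the source may bear on it.

In a functional assay on MCF cells (Homo sapiens) for antiproliferative activity, with a stated time of 72 h (on this read-out higher numbers stand for weaker inhibition and lower numbers for stronger inhibition), compound 1 `OC[C@H]1O[C@@H](n2cnc3c(NCc4ccc(Cl)cc4)ncnc32)[C@H](O)[C@@H]1O` reads > 166000 nM, which is a limit of the assay. Compound 2 `OC[C@H]1O[C@@H](n2cnc3c(NCc4ccc(Cl)cc4Cl)ncnc32)[C@H](O)[C@@H]1O` gives 127000 nM. Compound 3 `OC[C@H]1O[C@@H](n2cnc3c(NCc4cccc(O)c4O)ncnc32)[C@H](O)[C@@H]1O` gives 5200 nM, the lower of the two actual numbers in the series.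

Compound 4 `Cc1ccc(O)c(CNc2ncnc3c2ncn3[C@@H]2O[C@H](CO)[C@@H](O)[C@H]2O)c1` differs from compound 3 as follows: 2-hydroxy-5-methylphenyl in place of 2,3-dihydroxyphenyl on a saturated chain carbon bound to a nitrogen on an aromatic ring. It has 2-hydroxy-5-methylphenyl in place of 2,3-dihydroxyphenyl on a saturated chain carbon bound to a nitrogen on an aromatic ring.

For the measured compounds named here, no measured step isolates this exact change. The closest are a 24-fold lower number from compound 2 to compound 3 (1.39 log units; beyond the scatter) and an at least 31-fold lower number from compound 1 to compound 3 (1.50 log units; beyond the scatter), both large and both introducing the 2,3-dihydroxyphenyl group. The chloro step, an at least 1.3-fold lower number from compound 1 to compound 2 (0.11 log units; that floor lies within the scatter), has a floor within the scatter and offers little guidance.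

Compound 4 retains a hydroxy group but not the full 2,3-dihydroxyphenyl group of compound 3 at 5200 nM, so part of that large gain is expected to be lost. The estimated step in this assay is a 4.8-fold higher number from compound 3 to compound 4 (0.68 log units; beyond the scatter), towards a higher number. For compound 4 the expected value is 25000 nM, with an estimated range of 6000 nM to 100000 nM.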

Compound 4, half-maximal inhibitory concentration: > 166000 nM
Compound 4: no number, only a limit (the forecaster's own chance of this, stated with the estimate: 15%); middle value at least 6.6-fold (0.82 log units) away from the limit.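

In this assay compound 4 gives > 166000 nM, which is a limit of the assay. On a saturated chain carbon bound to a nitrogen on an aromatic ring, the change from 2,3-dihydroxybenzyl to 2-hydroxy-5-methylbenzyl gives an at least 31-fold higher number from compound 3 to compound 4 (1.50 log units; beyond the scatter), so in this pair one remaining hydroxy group does not keep the low number of compound 3. The chlorinated comparison reads an at least 1.3-fold higher number from compound 2 to compound 4 (0.11 log units; that floor lies within the scatter), which leaves the 2-hydroxy-5-methylphenyl and 2,4-dichlorophenyl groups unseparated, and the step involving compound 1 cannot be read, since two limits meet there: the limit of > 166000 nM in this assay, at which 2 of the 4 values shown sit.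

Going by these compounds, the loss of one hydroxy group and the arrival of the methyl occur together in compound 4, so their separate contributions stay open. On these data alone, whether a methoxy group or an amine in place of one hydroxy group of the 2,3-dihydroxyphenyl group would retain the value of compound 3 also stays open.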